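Lengthening a Chlorinated Chain in Three Measured Compounds

A few compounds are considered here, and "the series" means these few. Any claim that something is new, unique, unknown or untested is made for them only; others in the source may bear on it.

Measured in a functional assay on HT-1080 cells (Homo sapiens) for antiproliferative activity, read by sulforhodamine B assay, with a stated time of 48 h; on this read-out lower numbers stand for stronger inhibition and higher numbers for weaker inhibition:
Compound 1 `CC(C)c1ccccc1OS(=O)(=O)c1cccc(NC(=O)CCl)c1` gives 780 nM.
Compound 2 `CC(C)c1ccccc1OS(=O)(=O)c1cccc(NC(=O)CCCl)c1` gives 8200 nM.
Compound 3 `CC(C)c1ccccc1OS(=O)(=O)c1ccc(NC(=O)CCCl)cc1` gives 6500 nM.

Compound 1 and compound 2 differ in one place: chloromethyl in place of chloro on a saturated chain carbon bound to a carbonyl carbon. In this assay this change made an 11-fold higher number from compound 1 to compound 2 (1.02 log units; beyond the scatter), a step toward weaker inhibition. Compound 3 differs from compound 1 in more than one place, and the difference between the two cores is not broken down here; the values of compound 2 and compound 3 lie within the scatter of each other.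

Compound 4 `CC(C)c1ccccc1OS(=O)(=O)c1ccc(NC(=O)CCCCl)cc1` has not been measured. It differs from compound 3 in one place: chloromethyl in place of chloro on a saturated chain carbon, two bonds along the chain from a carbonyl carbon. Among the measured compounds shown here, this is the same kind of change as the one between compound 1 and compound 2, though the place differs: there the saturated chain carbon is bound to a carbonyl carbon, here it lies two bonds along the chain from a carbonyl carbon. Because the earlier step was an 11-fold higher number from compound 1 to compound 2 (1.02 log units; beyond the scatter), the step expected for compound 4 is a 2.3-fold higher number from compound 3 to compound 4 (0.36 log units; beyond the scatter). From the compounds shown here alone, whether the change acts alike at the new place is unknown, so the range is kept wide. The estimate for compound 4 in this assay is 15000 nM, between 6000 nM and 40000 nM.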

Compound 4, half-maximal inhibitory concentration: 3800 nM
Beside the measured number, compound 4's estimate is 3.9-fold (0.60 log units) above it, outside the stated range (below it).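

In this assay, putting chloromethyl in place of chloro on the chain of the second core gave a 1.7-fold lower number from compound 3 to compound 4 (0.23 log units; within the scatter), a step within the usual scatter of repeated measurements. The same change therefore did not keep its size from one core to the other: the same change on two cores in this assay, an 11-fold higher number (1.02 log units; beyond the scatter) from compound 1 to compound 2 and a 1.7-fold lower number (0.23 log units; within the scatter) from compound 3 to compound 4, 18-fold (1.25 log units) apart, beyond the scatter of two such steps. So the large step seen on the first core cannot simply be carried over to the second in this series, but these two pairs do not show why, and they set no rule for other chains or cores, as the change also sits at a different place on the chain in each pair.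

The compounds shown leave open how the shortest chain, the one in compound 1, would read on the core of compound 3, which would show the effect of the core on that chain directly. They also leave open whether a longer chain, or a chain ending in an amine instead of chlorine, would follow either step.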